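Sigma receptor binding: ring-nitrogen substituent exchange in compound 1

A few compounds are considered here, and "the series" means these few. Any claim that something is new, unique, unknown or untested is made for them only; others in the source may bear on it.

Measured so far:
compound 1 `[O-][S+](CCNC1CCN(CC(O)Cc2ccccc2)CC1)C(c1ccc(F)cc1)c1ccc(F)cc1` — 351 nM
compound 2 `CC(C)(C)CN1CCC(NCCSC(c2ccc(F)cc2)c2ccc(F)cc2)CC1` — 315 nM

Two compounds of this series have a number in an assay on membranes from Cortex for displacement of a labelled ligand from Sigma non-opioid intracellular receptor 1 (Cavia porcellus), read by scintillation counting, with a stated time of 120 min; a higher number here means a weaker inhibitor, a lower number a stronger inhibitor. Compound 1 gives 351 nM, and compound 2 gives 315 nM. Compound 1 carries the higher of the two numbers, but the gap to compound 2 lies within the scatter, so the two read as equivalent and no order between them is claimed. For the measured compounds named here, no pair of measured compounds differing in one place is available, so no measured step size exists to lean on.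

Compound 3 `O=C(c1ccccc1F)N1CCC(NCC[S+]([O-])C(c2ccc(F)cc2)c2ccc(F)cc2)CC1` is not yet measured in this assay. It differs from compound 1 in one place: (2-fluorophenyl)carbonyl in place of 2-hydroxy-3-phenylpropyl on an amine nitrogen in a ring. Going by the values given here, this is the only change between the two structures; the rest of the molecule, including the sulfinyl-bearing side chain, is kept.

Nothing in the two measured numbers tells which way this exchange moves the inhibition constant. The working expectation is a modest weakening, a step from compound 1 to compound 3 of about a 2.0-fold higher number from compound 1 to compound 3 (0.30 log units; within the scatter), though a result within the scatter would not surprise. Compound 3 is therefore estimated at 700 nM, with a plausible range from 200 nM to 2500 nM.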

Compound 3, inhibition constant: 1310 nM
Compound 3: middle estimate off by 1.9-fold (0.27 log units), on the low side, and the stated range covers the measured number.
By their numbers in this assay, from the lowest: compounds 2 and 1 (each within the scatter of the next); then compound 3.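

In this assay, for the compounds shown here, (2-fluorophenyl)carbonyl in place of 2-hydroxy-3-phenylpropyl on the amine nitrogen in the ring gives a 3.7-fold higher number from compound 1 to compound 3 (0.57 log units; beyond the scatter), the first measured step and a weakening beyond the scatter. This substituent position is therefore not indifferent to exchange: with the rest of the molecule kept, this single change moves the inhibition constant, even though both groups carry one six-membered aromatic ring of carbon only. No measurement available here connects the step to any particular feature of either group.

Going by these compounds, the exchange changes several things at once, including the hydroxyl, the carbonyl and the fluorine, so it remains open whether a 3-phenylpropyl group without the hydroxyl or a plain benzoyl group without the fluorine would give a number closer to compound 1 or to compound 3. Also open, on these data alone, is whether the same exchange would give a step of similar size and direction on the side chain of compound 2, which differs from compound 1 in more than one place.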